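Swapping a Benzyl Substituent on a Shared Core

The compounds below may be only part of what the source reports. "The series", "measured", "known", "first", "only" and "open" are said of these compounds alone.

Of the compounds shown here, three built on the same core have been measured in a functional assay on RAW264.7 cells (Mus musculus) for inhibition, read by Griess assay, with stated times of 2 h and 24 h; a lower number here means a stronger inhibitor, a higher number a weaker inhibitor. Compound 1 `CCCCn1cc(COc2cc(O)c3c(c2)O[C@H](c2ccc(OC)c(O)c2)C/C3=N\O)nn1` gives 8900 nM in this assay. Compound 3 `COc1ccc([C@@H]2C/C(=N\O)c3c(O)cc(OCc4cn(C5CCCC5)nn4)cc3O2)cc1O` gives 6880 nM in this assay. Compound 2 `COc1ccc([C@@H]2CC(=O)c3c(O)cc(OCc4cn(Cc5ccc(C)cc5)nn4)cc3O2)cc1O` gives 16800 nM in this assay, the highest of the three numbers, meaning the weakest inhibition shown so far; its gap to compound 1 lies within the scatter, while its gap to compound 3 lies beyond it.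

Within the data shown here, the one measured pair that differs in a single place is the swap of cyclopentyl for butyl on an aromatic nitrogen, and there a 1.3-fold lower number from compound 1 to compound 3 (0.11 log units; within the scatter).

Compound 4 `COc1ccc([C@@H]2CC(=O)c3c(O)cc(OCc4cn(Cc5cccc(Cl)c5)nn4)cc3O2)cc1O` is not yet measured. It differs from compound 2 by 3-chlorophenyl in place of 4-methylphenyl on a saturated chain carbon bound to an aromatic nitrogen. Among the measured compounds shown here, no measured pair exchanges one substituted phenyl for another on that saturated chain carbon, so nothing in the data speaks directly to this change, and the only single-place step seen is within the scatter. The expectation is therefore a step of a 1.1-fold lower number from compound 2 to compound 4 (0.05 log units; within the scatter), with no clear direction beyond the scatter. Compound 4 is expected to give about 15000 nM in this assay, within a range from 6000 nM to 40000 nM.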

Compound 4, half-maximal inhibitory concentration: 18200 nM
Compound 4: middle estimate off by 1.2-fold (0.08 log units), on the low side, and the stated range covers the measured number.
By their numbers in this assay, from the lowest: compounds 3, 1, 2 and 4 (each within the scatter of the next, the first and the last beyond it).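

In this assay, replacing 4-methylphenyl with 3-chlorophenyl on the saturated chain carbon bound to an aromatic nitrogen gives a 1.1-fold higher number from compound 2 to compound 4 (0.03 log units; within the scatter) on the shared core. Among these compounds, this is the first measured exchange of one substituted phenyl for another at this place, and it shows that these two groups cannot be told apart in this read-out, even though both the substituent and its location on the ring differ. No measurement is available that could explain this result or show whether the two differences cancel out or simply have little effect.

Since the substituent and its location change together, this pair cannot separate them, and 3-methylphenyl or 4-chlorophenyl at the same place would be needed to do so. Both groups compared here also carry only a single methyl or chlorine on the phenyl ring, so the compounds shown leave open whether a carboxylic acid or an amine on that ring, or a longer chain in place of the benzyl link, would move the number beyond the scatter.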